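A Chloro-Methyl Pyridine Swap in a Urea Series

The compounds below may be only part of what the source reports. "The series", "measured", "known", "first", "only" and "open" are said of these compounds alone.

Compound 1, `Cc1cc(CNC(=O)Nc2cc(Cl)nc(OCC(F)F)c2)nnc1-c1cn(C)nc1C(F)(F)F`, gives 71000 nM in a functional assay on HFL1 cells for antagonist activity at sphingosine 1-phosphate receptor 2 (Homo sapiens), read by ELISA, with a stated time of 24 h, in the presence of a further agent that is not named here; a lower number here means a stronger inhibitor, a higher number a weaker inhibitor.
Compound 2, `CCOc1cc(NC(=O)NCc2cc(C)c(-c3cn(C)nc3C(F)(F)F)nn2)cc(C#N)n1`, gives 67000 nM.
Compound 3, `CCOc1nc(C#N)cc(NC(=O)NCc2cc(C)c(-c3cn(C)nc3C(F)(F)F)nn2)c1C`, gives 17000 nM.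

Compound 2 holds the second highest of the three numbers: compound 1 sits within the scatter of it, while compound 3 lies furthest away. Compound 4, `CCOc1nc(C)cc(NC(=O)NCc2cc(C)c(-c3cn(C)nc3C(F)(F)F)nn2)c1Cl`, is not yet measured and differs from compound 2 by 3-chloro-2-ethoxy-6-methylpyridin-4-yl in place of 2-cyano-6-ethoxypyridin-4-yl on an amide-type nitrogen. Among the measured compounds shown here, only one measured step bears on this change: a 3.9-fold lower number from compound 2 to compound 3 (0.60 log units; beyond the scatter), a modest lowering from a group added on an aromatic carbon. The new change likewise places a group on an aromatic carbon, though a different one, so a step of similar size downward is expected, a 3.4-fold lower number from compound 2 to compound 4 (0.53 log units; beyond the scatter). Compound 4 is therefore estimated at 20000 nM, with a likely range from 6000 nM to 60000 nM.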

Compound 4, half-maximal inhibitory concentration: 49000 nM
Compound 4: the middle estimate sits 2.5-fold (0.39 log units) below what was measured; the range from low to high includes it.
By their numbers in this assay, from the lowest: compound 3; then compounds 4, 2 and 1 (each within the scatter of the next).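

In this assay, the change on the amide-type nitrogen gives a 1.4-fold lower number from compound 2 to compound 4 (0.14 log units; within the scatter), so removing the nitrile while adding a chlorine and a methyl leaves the number within the scatter. The single added methyl, by contrast, gave a 3.9-fold lower number from compound 2 to compound 3 (0.60 log units; beyond the scatter), a step beyond the scatter. No measurement here explains this difference.

As far as these compounds go, what the chlorine and the methyl each contribute alone remains open, since they enter together with the loss of the nitrile. Also open, from the compounds shown here alone, is how a 3-bromo or 3-methoxy group would compare with the 3-chloro group.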